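Fluoro Substitution Series: Working Notes on Maximal Response

The source may report more compounds than this note shows. Statements on the series, on what has been measured and on what is new or still open speak of the compounds shown alone.

Measured so far:
compound 1 `O=C1C=C(Nc2ccccc2)C(=O)c2cnccc21`: 93%
compound 2 `O=C1C=C(Nc2cccc(F)c2)C(=O)c2cnccc21`: 89%
compound 3 `O=C1C=C(Nc2ccc(F)cc2F)C(=O)c2cnccc21`: 96%

In a functional assay on the whole organism (aorta) with Rattus norvegicus as the target (a higher number here means a larger maximal response, a lower number a smaller maximal response), compound 1 gives 93%. Compound 2 carries the change (fluoro in place of hydrogen on an aromatic carbon), and the step is a number 4 percentage points lower from compound 1 to compound 2 (within the scatter). Compound 3 gives 96% in this assay; its value and those of compound 1 and compound 2 all lie within the scatter of one another, so no order among the three can be read from them. The difference between the cores of compound 1 and compound 3 is not broken down here.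

Compound 4 `O=C1C=C(Nc2ccc(F)c(F)c2F)C(=O)c2cnccc21` has not yet been measured in this assay. Relative to compound 3 it carries fluoro in place of hydrogen on an aromatic carbon. Among the compounds with values here, this is the same kind of change as the one from compound 1 to compound 2, but the surroundings differ: in compound 2 the entering fluoro is meta to a large group only, whereas in compound 4 it is ortho to two fluoro groups (1 heavy atom each) and meta to a large group.

For compound 4 the expected step is a number 3 percentage points lower from compound 3 to compound 4 (within the scatter). It is placed beside the earlier step because a number 4 percentage points lower from compound 1 to compound 2 (within the scatter) is within the scatter and a small change of the same kind is all that is added. The estimate for compound 4 is 93%, expected to fall between 84% and 100%.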

Compound 4, largest response reached (Emax), in percent of the reference or control that the assay uses: 87%
The estimate for compound 4 lay 6 percentage points above the measured number; measured number inside the range.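

In this assay, fluoro in place of hydrogen on an aromatic carbon gives a step that reads a number 9 percentage points lower from compound 3 to compound 4 (within the scatter), here with the entering fluoro ortho to two fluoro groups and meta to a large group. Set beside the earlier step, a number 4 percentage points lower from compound 1 to compound 2 (within the scatter), this gives no sign that the outcome of the change depends on the core in this series, and neither step can be read as a real shift in maximal response. The comparison does not show that the change is without effect or that it would carry over equally to other cores, as it rests on two pairs whose surroundings differ, and its measured result is as follows: the same change on two cores in this assay, a number 4 percentage points lower (within the scatter) from compound 1 to compound 2 and a number 9 percentage points lower (within the scatter) from compound 3 to compound 4, 5 percentage points apart, within the scatter of two such steps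

The compounds shown carry only fluoro on the six-membered aromatic ring of carbon only, so the same positions with chloro, methoxy, a nitrile, an amine, a carboxylic acid or a longer chain remain open. From the compounds shown here alone, all of them also share a single kind of attachment to that ring, and whether a replacement of the amine link would leave the maximal response in the same range is also open.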